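Methoxy Gives Way to Fluoro on the Pendant Aryl Ring

The source may hold more compounds than are shown below. What is called first, only, known or untested is meant among the compounds shown, and "the series" means these compounds.

Of the compounds shown here, three sharing one core have been measured in a functional assay, tested at 200 ug/mL; a higher number here means a stronger effect of the compound at the concentration tested, a lower number a weaker effect. Compound 1 `Cc1ccccc1C1C(C#N)=C(N)OC(c2c[nH]c3ccccc23)=C1C#N` gives 21.4%, compound 2 `Cc1ccc(C2C(C#N)=C(N)OC(c3c[nH]c4ccccc34)=C2C#N)cc1` gives 6.2%, and compound 3 `COc1ccc(C2C(C#N)=C(N)OC(c3c[nH]c4ccccc34)=C2C#N)cc1` gives 26.4%. For the measured compounds named here, compound 3 carries the highest number of the three, though its gap to compound 1 lies within the scatter; only the step of a number 20.2 percentage points higher from compound 2 to compound 3 (beyond the scatter) stands beyond it. The change from compound 3 to compound 4 `N#CC1=C(N)OC(c2c[nH]c3ccccc23)=C(C#N)C1c1ccc(F)cc1` is fluoro in place of methoxy on an aromatic carbon. Going by the values given here, no measured step replaces methoxy with fluoro, so the bearing comes only indirectly, through the step of a number 20.2 percentage points higher from compound 2 to compound 3 (beyond the scatter), which shows that a change on the same aromatic carbon can shift this assay modestly, and through a number 15.2 percentage points lower from compound 1 to compound 2 (beyond the scatter), which shows the aryl ring matters. Among the compounds with values here, because 6.2% for compound 2 is the only other number with a small group at that position, a modest fall back toward it is expected, a number 11.4 percentage points lower from compound 3 to compound 4 (beyond the scatter). Compound 4 is therefore estimated at 15%, within 4% to 28%.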

Compound 4, a percentage reported as activity, at one concentration (the size of the read-out at that concentration, not a potency): 22.4%
The estimate for compound 4 lay 7.4 percentage points below the measured number, within the range that was stated.
By their numbers in this assay, from the lowest: compound 2; then compounds 1, 4 and 3 (each within the scatter of the next).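

In this assay, the direct swap of 4-methoxyphenyl for 4-fluorophenyl gives a number 4 percentage points lower from compound 3 to compound 4 (within the scatter), so the two groups cannot be told apart at this position. Against methyl on the same aromatic carbon, the fluoro group gives a number 16.2 percentage points higher from compound 2 to compound 4 (beyond the scatter), which leaves compound 2 set apart from both compound 3 and compound 4, with methyl the only one of these three groups whose number stands off from the others. The 4-fluorophenyl group also reads level with the 2-methylphenyl group of compound 1, at a number 1 percentage points higher from compound 1 to compound 4 (within the scatter).

From the compounds shown here alone, whether an amine, a carboxylic acid or a longer chain on that aromatic carbon would read with compound 3 and compound 4 or fall toward compound 2 remains open. No measurement at hand explains why methyl stands apart from fluoro and methoxy.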